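This account rests on a few compounds, and the source may have more. Where it says the series, first, only, none or still open, it means among the compounds named here.

In a functional assay on Caco-2 cells (Homo sapiens) for inhibition, read by sulforhodamine B assay, with a stated time of 48 h (a higher number here means a weaker inhibitor, a lower number a stronger inhibitor), compound 1 `CCO[C@H]1C[C@@H](c2coc3ccccc3c2=O)N(c2ccccc2)O1` gives > 60000 nM, which is a limit and not a number. Compound 2 `O=c1c([C@@H]2C[C@H](c3ccccc3)ON2c2ccccc2)coc2ccccc12` gives > 60000 nM, again a limit. Together they stand at the limit of > 60000 nM in this assay, at which 2 of the 2 values shown sit. For the measured compounds named here, the only measured step is a step that the two limits leave unreadable from compound 1 to compound 2, so it offers no size to carry forward. Compound 3 `O=c1c([C@@H]2C[C@H](c3ccncc3)ON2c2ccccc2)coc2ccccc12` differs from compound 2 in one place: pyridin-4-yl in place of phenyl on a saturated ring carbon. With no readable step to draw on, no change beyond the usual scatter is expected in this assay. The estimated step is a number no higher from compound 2 to compound 3 (the limit leaves the size open). Compound 3 is expected at 60000 nM, within an estimated range of 25000 nM to 120000 nM.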

Compound 3, half-maximal inhibitory concentration: 37000 nM
Estimate against measurement, compound 3: 1.6-fold (0.21 log units) above, within the range that was stated.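

In this assay, for the compounds shown here, compound 3, with pyridin-4-yl on the saturated ring carbon next to the ring oxygen, is the first compound here to give a number and not a limit. Phenyl replaced by pyridin-4-yl gives an at least 1.6-fold lower number from compound 2 to compound 3 (0.20 log units; that floor lies within the scatter) and ethoxy replaced by pyridin-4-yl gives an at least 1.6-fold lower number from compound 1 to compound 3 (0.20 log units; that floor lies within the scatter) so a change at this position can now be read, though only as a floor. Most of the series still rests on a limit: the limit of > 60000 nM in this assay, at which 2 of the 3 values shown sit.

On these data alone, the true size of both steps stays open. So does whether an amine or a carboxylic acid on this ring carbon would give a lower number.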